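This account rests on a few compounds, and the source may have more. Where it says the series, first, only, none or still open, it means among the compounds named here.

Measured compounds:
- compound 1, `CN(C)c1nc(N)c2ncn([C@@H]3C[C@@H](O)[C@H](CO)O3)c2n1`: in a functional assay on MOLT-4 cells (Homo sapiens) (on this read-out higher numbers stand for weaker inhibition and lower numbers for stronger inhibition), compound 1 gives > 300 uM, which is a limit of the assay and not a number
- compound 2, `CSc1nc(SC)c2ncn([C@@H]3C[C@@H](O)[C@H](CO)O3)c2n1`: in this assay compound 2 gives 141 uM

Among the measured compounds shown here, compound 2 is the only one of the pair with a numerical result; the other result is a limit (the limit of > 300 uM in this assay, at which 1 of the 2 values shown sits). Compound 3, `CNc1nc(SC)nc2c1ncn2[C@@H]1C[C@@H](O)[C@H](CO)O1`, has not yet been measured in this assay. It differs from compound 2 by methylamino in place of methylsulfanyl on an aromatic carbon. The move goes toward the substitution pattern of compound 1, which carries only amino-type groups on the shared core and gave only a limit. A step toward weaker inhibition is expected, possibly beyond the scatter, with a fair chance of another limit. Compound 3 is estimated at 250 uM, range 90 uM to 700 uM, an expected step of a 1.8-fold higher number from compound 2 to compound 3 (0.25 log units; within the scatter).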

Compound 3, concentration for 50% inhibition: > 300 uM
Compound 3 was reported as a limit; the forecaster's own chance of this, stated with the estimate: 40%; middle value at least 1.2-fold (0.07 log units) from the limit.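

In this assay, methylamino in place of methylsulfanyl on an aromatic carbon next to the ring nitrogen gives an at least 2.1-fold higher number from compound 2 to compound 3 (0.32 log units; beyond the scatter). Among the compounds shown here, this is the first comparison with a single change, and it shows that this position alone can move the read-out beyond the scatter while the other methylsulfanyl group stays in place; compound 1 differs from compound 2 in more than one place and could not show this. The size of the step remains open at its upper end, as the result for compound 3 is a limit of the assay and not a number: the limit of > 300 uM in this assay, at which 2 of the 3 values shown sit.

Whether the loss follows from removing methylsulfanyl or from introducing methylamino remains unresolved. Methoxy or ethylsulfanyl at this position would help separate the two, and the effect of changing the other methylsulfanyl group on its own is also open.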